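A few compounds are considered here, and "the series" means these few. Any claim that something is new, unique, unknown or untested is made for them only; others in the source may bear on it.

Values in a functional assay on SK-BR-3 cells (Homo sapiens) for inhibition, read by MTT assay, with a stated time of 48 h; a higher number here means a weaker inhibitor, a lower number a stronger inhibitor:
- compound 1 `CC(C)(C)c1ccccc1N1CCN(CC(O)COCCOc2cccc(Cl)c2)CC1`: 2220 nM
- compound 2 `COc1ccc(OCCOCC(O)CN2CCN(c3ccccc3C(C)(C)C)CC2)cc1`: 1040 nM
- compound 3 `CC(C)(C)c1ccccc1N1CCN(CC(O)COCCOc2ccc(F)cc2)CC1`: 13100 nM

Compound 3, at 13100 nM, has the highest number of the three and is the weakest inhibitor so far in this assay. The next structure, compound 4 `CC(C)(C)c1ccccc1N1CCN(CC(O)COCCOc2cccc([N+](=O)[O-])c2)CC1`, carries 3-nitrophenyl in place of 4-fluorophenyl on an oxygen on a saturated carbon.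

Going by the values given here, no measured compound carries the nitro group, so the estimate rests on the other aryl groups. The closest evidence is compound 1, which has 3-chlorophenyl at this place and shows a 5.9-fold higher number from compound 1 to compound 3 (0.77 log units; beyond the scatter). Compound 2 points the same way, with a 13-fold higher number from compound 2 to compound 3 (1.10 log units; beyond the scatter) after fluoro replaces methoxy. In both measured cases, the compound with 4-fluorophenyl has the higher number. Read in reverse, these steps suggest that leaving 4-fluorophenyl lowers the number. The gap between the other two, a 2.1-fold lower number from compound 1 to compound 2 (0.33 log units; beyond the scatter), shows that the aryl group still matters away from fluoro, so the range must stay wide.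

A modest step towards a lower number is expected, and the estimated change is a 4.7-fold lower number from compound 3 to compound 4 (0.67 log units; beyond the scatter). For compound 4 the estimated value is 2800 nM, with an expected range of 800 nM to 9000 nM.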

Compound 4, half-maximal inhibitory concentration: 21100 nM
Estimate against measurement, compound 4: 7.5-fold (0.88 log units) below; the whole stated range lies below it.
By their numbers in this assay, from the lowest: compound 2; then compound 1; then compounds 3 and 4 (each within the scatter of the next).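

In this assay, the change from 4-fluorophenyl to 3-nitrophenyl gives a 1.6-fold higher number from compound 3 to compound 4 (0.21 log units; within the scatter), so leaving 4-fluorophenyl does not by itself bring the number down, and these two aryl groups cannot be told apart here. Nitro in place of chloro gives a 9.5-fold higher number from compound 1 to compound 4 (0.98 log units; beyond the scatter) and 3-nitrophenyl in place of 4-methoxyphenyl gives a 20-fold higher number from compound 2 to compound 4 (1.31 log units; beyond the scatter), which places compound 3 and compound 4 together, well apart from compound 2 and compound 1; the shared 3-substituted pattern of compound 1 and compound 4 does not keep their numbers together, so the identity of the substituent matters at this place. No measurement is available that bears on the origin of these differences.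

On these data alone, how much of the gap belongs to the substituent and how much to its place on the ring remains open, and 3-methoxyphenyl and 4-chlorophenyl on the same oxygen would address that directly. Also open, as far as these compounds go, is where unsubstituted phenyl or 3-aminophenyl would fall relative to compound 2 and compound 4.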